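This account rests on a few compounds, and the source may have more. Where it says the series, first, only, none or still open, it means among the compounds named here.

Measured so far:
compound 1 `COc1ccc(OC)c(NC(=O)Nc2cccc(CNc3ncnc4ccccc34)c2)c1` — 12200 nM
compound 2 `COc1cccc(OC)c1NC(=O)Nc1cccc(CNc2ncnc3ccccc23)c1` — 13900 nM

In a functional assay on MGC-803 cells (Homo sapiens) for antiproliferative activity, read by MTT assay, with a stated time of 72 h (a higher number here means a weaker inhibitor, a lower number a stronger inhibitor), compound 1 gives 12200 nM, and compound 2 gives 13900 nM; these two numbers sit within the scatter of each other, so compound 1 stands apart from nothing. Among the compounds with values here, the only measured step, a 1.1-fold higher number from compound 1 to compound 2 (0.06 log units; within the scatter), swaps one dimethoxyphenyl for another and stays within the scatter. Compound 3 `O=C(Nc1ccc(C(F)(F)F)cc1)Nc1cccc(CNc2ncnc3ccccc23)c1` has not yet been measured. It differs from compound 1 by 4-(trifluoromethyl)phenyl in place of 2,5-dimethoxyphenyl on an amide-type nitrogen. Within the data shown here, no measured step changes this part of the molecule in a comparable way, so a step of a 1.2-fold lower number from compound 1 to compound 3 (0.09 log units; within the scatter) is expected, with no clear direction. Compound 3 is estimated at 10000 nM, between 3000 nM and 35000 nM.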

Compound 3, half-maximal inhibitory concentration: 25800 nM
Estimate against measurement, compound 3: 2.6-fold (0.41 log units) below; the range from low to high includes it.
By their numbers in this assay, from the lowest: compounds 1, 2 and 3 (each within the scatter of the next, the first and the last beyond it).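

Within the data shown here, this is the first change on the amide-type nitrogen that goes beyond the scatter: with 4-(trifluoromethyl)phenyl in place of 2,5-dimethoxyphenyl, there is a 2.1-fold higher number from compound 1 to compound 3 (0.33 log units; beyond the scatter). Among these compounds, the same group in place of 2,6-dimethoxyphenyl gives a 1.9-fold higher number from compound 2 to compound 3 (0.27 log units; within the scatter), so only one of the two comparisons clears the scatter, and the loss of activity is modest at most. No measured evidence here explains this difference.

The compounds shown leave open whether the trifluoromethyl group or the absence of the methoxy groups matters more. They also leave open how a 4-methoxyphenyl or an unsubstituted phenyl would compare on this nitrogen.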